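This account rests on a few compounds, and the source may have more. Where it says the series, first, only, none or still open, it means among the compounds named here.

Measured so far in an ADME assay on microsomes from liver (Rattus norvegicus) for metabolic stability, with a stated time of 40 min, tested at 10 uM; a higher number here means that more of the compound is left, a lower number that less of the compound is left:
compound 1 `CCS(=O)(=O)Nc1ccc(Oc2cc(F)c(F)c(F)c2)c(-c2cn(C)c(=O)c3cncn23)c1` — 54.3%
compound 2 `Cn1cc(-c2cc(NS(C)(=O)=O)ccc2Oc2ccc(F)cc2)n2cncc2c1=O` — 78%

Compound 1 stands lowest of the two numbers in this assay; compound 2 lies higher by a gap beyond the scatter. For the measured compounds named here, no step between measured compounds shares the change now considered, so nothing measured speaks directly to it.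

Compound 3 `CCS(=O)(=O)Nc1ccc(Oc2ccc(C(C)C)cc2)c(-c2cn(C)c(=O)c3cncn23)c1` has not been measured. It differs from compound 1 by 4-isopropylphenyl in place of 3,4,5-trifluorophenyl on an oxygen on an aromatic ring.

Going by the values given here, with no matching step to lean on, a downward step in this assay is expected for compound 3, beyond the scatter, namely a number 19.3 percentage points lower from compound 1 to compound 3 (beyond the scatter). Compound 3 is estimated at 35%, expected to fall between 15% and 58%.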

Compound 3, percent of the compound remaining: 3.9%
For compound 3 the middle estimate is 31.1 percentage points above the measured one; the whole stated range lies above it.
By their numbers in this assay, from the lowest: compound 3; then compound 1; then compound 2.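

In this assay the aryl group on an oxygen on an aromatic ring proves a sensitive position: 4-isopropylphenyl in place of 3,4,5-trifluorophenyl gives a number 50.4 percentage points lower from compound 1 to compound 3 (beyond the scatter). With the rest of the structure unchanged, this one change takes compound 3 to the bottom of the three compounds. Nothing at hand bears on the reason for the step.

As far as these compounds go, whether the step follows from the loss of the fluorines or from the arrival of the isopropyl group stays open. So does the standing of a plain phenyl or a 4-methoxyphenyl on the same oxygen.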